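Sulfonyl aryl changes and hepatic clearance in the series

The compounds below may be only part of what the source reports. "The series", "measured", "known", "first", "only" and "open" are said of these compounds alone.

Compound 3 `Cc1ccc(S(=O)(=O)c2cnc3c(F)cccc3c2-c2ccc(F)cc2)cc1F` gives 2.75 mL/min in an ADME assay on microsomes from liver (Homo sapiens) for metabolic stability, tested at 2.5 uM (on this read-out lower numbers stand for slow clearance and higher numbers for fast clearance), the highest of the three numbers measured; compound 2 `O=S(=O)(c1cc(Cl)cc(Cl)c1)c1cnc2c(F)cccc2c1-c1ccc(F)cc1` gives 1.01 mL/min, and compound 1 `O=S(=O)(c1ccc(F)c(F)c1)c1cnc2c(F)cccc2c1-c1ccc(Cl)cc1` gives 0.28 mL/min. Going by the values given here, the only single-place step measured, a 2.7-fold higher number from compound 2 to compound 3 (0.44 log units; beyond the scatter), shows that the aryl on the sulfonyl sulfur shifts this read-out by a modest amount. Compound 4 `O=S(=O)(c1ccc(F)c(F)c1)c1cnc2c(F)cccc2c1-c1ccc(F)cc1` differs from compound 3 by fluoro in place of methyl on an aromatic carbon. Among the compounds with values here, compound 1 carries the same 3,4-difluorophenyl and gives the lowest number, 0.28 mL/min, but it differs from compound 4 in a second place, so no direct step bears on it. A downward step is nevertheless expected in this assay, a 4.6-fold lower number from compound 3 to compound 4 (0.66 log units; beyond the scatter), beyond the scatter. Compound 4 is estimated at 0.6 mL/min, between 0.2 mL/min and 1.6 mL/min.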

Compound 4, intrinsic clearance in a liver preparation (reported as CLH), per the amount of preparation that the assay uses: 0.78 mL/min
Estimate against measurement, compound 4: 1.3-fold (0.11 log units) below; the measured number falls inside the stated range.
By their numbers in this assay, from the lowest: compound 1; then compounds 4 and 2 (each within the scatter of the next); then compound 3.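

In this assay, going by these compounds alone, fluoro in place of methyl on the aromatic carbon ortho to a fluoro group gives a 3.5-fold lower number from compound 3 to compound 4 (0.55 log units; beyond the scatter), the first direct reading at this position. The fluoro and chloro change on the other aryl also gets a direct reading in a 2.8-fold higher number from compound 1 to compound 4 (0.44 log units; beyond the scatter), whereas 3,4-difluorophenyl and 3,5-dichlorophenyl on the sulfonyl sulfur remain level in a 1.3-fold lower number from compound 2 to compound 4 (0.11 log units; within the scatter). No measurement bears on why these numbers shift. As far as these compounds go, whether methoxy, nitrile or an amine at this position would give a similar number remains open, as does whether the fluoro and chloro step holds with other sulfonyl aryls.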